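This account rests on a few compounds, and the source may have more. Where it says the series, first, only, none or still open, it means among the compounds named here.

Working notes on the series in an ADME assay on MDCK cells (Canis lupus familiaris) for cytotoxicity, with a stated time of 48 h; a lower number here means that less compound is tolerated, a higher number that more compound is tolerated. Among the measured compounds shown here, compound 1 `CC(C)OCCCNC(=O)c1csc(Nc2ccc(Cl)c(Cl)c2)n1` gives 100000 nM and is the only member of the set with a plain number. Compound 2 `CCOCCCNC(=O)c1csc(Nc2ccc(Cl)c(Cl)c2)n1` gives > 100000 nM, which is a limit of the assay. Compound 3 `CC(C)OCCCNC(=O)c1csc(Nc2cc(Cl)c(Cl)c(Cl)c2)n1` gives > 100000 nM, again a limit of the assay. The two steps from compound 1 therefore read as a number no lower from compound 1 to compound 2 (the limit leaves the size open) for hydrogen in place of methyl on the ether chain and a number no lower from compound 1 to compound 3 (the limit leaves the size open) for chloro in place of hydrogen on the aromatic ring; neither has a readable size, since both end at the limit of > 100000 nM in this assay, at which 2 of the 3 values shown sit.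

Compound 4 `CC(C)OCCCNC(=O)c1csc(Nc2ccc(Cl)cc2)n1` is the next member to be run. Relative to compound 1 the change is hydrogen in place of chloro on an aromatic carbon, so the aromatic ring of compound 1 loses one of its two chloro groups. For the measured compounds named here, the only measured step on this ring runs the other way, from compound 1 to compound 3, where a chloro enters and the value moves no lower; nothing among the measured steps shows a chloro leaving. With both ring variants sitting at or near the top of the assay window, the step expected is no change at the digits printed from compound 1 to compound 4 (within the scatter), within the usual scatter. For compound 4 the estimate is 100000 nM, with a range from 40000 nM to 200000 nM.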

Compound 4, half-maximal cytotoxic concentration: > 100000 nM
Compound 4: a limit, no number (the forecaster's own chance of this, stated with the estimate: 50%); the middle value lies on the limit itself.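

Among the compounds shown here, the step from 3,4-dichlorophenyl to 4-chlorophenyl is the first on this ring in which a chloro leaves, and in this assay it reads as a number no lower from compound 1 to compound 4 (the limit leaves the size open). Together with the step in which a chloro enters, it shows that neither change on this ring brings the number lower than that of compound 1. None of the three steps from compound 1 can be read for size, because each ends at the same limit: the limit of > 100000 nM in this assay, at which 3 of the 4 values shown sit.

The compounds shown leave open how large any of these steps is, and whether any change at this ring position or on the ether chain lowers the tolerated concentration. On these data alone, whether an amine or a carboxylic acid on the aromatic ring, or a longer chain on the ether oxygen, would give a plain number in this assay also stays open.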